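Benzyl variation on the shared core

The compounds below may be only part of what the source reports. "The series", "measured", "known", "first", "only" and "open" are said of these compounds alone.

Measured so far:
compound 1, `O=c1ccoc2cc(OCc3cn(Cc4ccc([N+](=O)[O-])cc4)nn3)ccc12`, > 100000 nM
compound 2, `Cc1ccccc1Cn1cc(COc2ccc3c(=O)ccoc3c2)nn1`, > 100000 nM

In a functional assay on QGY7701 cells (Homo sapiens) for cytotoxicity, read by MTT assay, with a stated time of 48 h (on this read-out lower numbers stand for stronger inhibition and higher numbers for weaker inhibition), compound 1 gives only a limit, > 100000 nM. In this assay compound 2 likewise gives only a limit, > 100000 nM. Among the compounds with values here, the one measured step, a step that the two limits leave unreadable from compound 1 to compound 2, is therefore unreadable, and compound 2 stands at the assay ceiling, as the limit of > 100000 nM in this assay, at which 2 of the 2 values shown sit, shows.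

Compound 3, `O=c1ccoc2cc(OCc3cn(Cc4ccc(Cl)cc4)nn3)ccc12`, differs from compound 2 by 4-chlorophenyl in place of 2-methylphenyl on a saturated chain carbon bound to an aromatic nitrogen. No readable step bears on this change. Compound 3 is expected to show no step beyond the scatter, a step that the limit leaves unreadable from compound 2 to compound 3, and most likely a limit again. The estimate for compound 3 is 150000 nM, within 50000 nM to 500000 nM.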

Compound 3, half-maximal inhibitory concentration: 41700 nM
The estimate for compound 3 lay 3.6-fold (0.56 log units) above the measured number; measured number below the stated range.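

In this assay, 4-chlorophenyl in place of 2-methylphenyl gives an at least 2.3-fold lower number from compound 2 to compound 3 (0.37 log units; beyond the scatter) and shows that a change on the saturated chain carbon bound to an aromatic nitrogen can bring a measurable number into this series. Chloro in place of nitro on an aromatic carbon gives an at least 2.3-fold lower number from compound 1 to compound 3 (0.37 log units; beyond the scatter) and so also separates compound 3 from compound 1. Both steps remain lower bounds, and compound 3 alone has a number: the limit of > 100000 nM in this assay, at which 2 of the 3 values shown sit.

From the compounds shown here alone, whether an amine or a carboxylic acid on that aromatic carbon would lower the number further remains open. So does the effect of a longer chain in place of the benzyl group.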